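The source may report more compounds than this note shows. Statements on the series, on what has been measured and on what is new or still open speak of the compounds shown alone.

In a functional assay on MCF7 cells (Homo sapiens) for antiproliferative activity, read by sulforhodamine B assay, with a stated time of 48 h (on this read-out lower numbers stand for stronger inhibition and higher numbers for weaker inhibition), compound 1 `Cc1ccc(OS(=O)(=O)c2ccc(N3CCN(C)C3=O)cc2)cc1` gives > 100000 nM, which is a limit and not a number. Compound 2 `CCCN1CCN(c2ccc(S(=O)(=O)Oc3c(Cl)cc(Cl)cc3Cl)cc2)C1=O` gives > 100000 nM, which is also only a limit. Going by the values given here, compound 3 `CCCN1CCN(c2ccc(S(=O)(=O)Oc3cccc(Cl)c3)cc2)C1=O` gives 380 nM, the only true number among the three.

The next structure is compound 4 `CCCN1CCN(c2ccc(S(=O)(=O)Oc3ccc(C)cc3)cc2)C1=O`, and the change is 4-methylphenyl in place of 3-chlorophenyl on an oxygen. One measured step involves the same place. Putting 3-chlorophenyl in place of 2,4,6-trichlorophenyl on that oxygen gave an at least 260-fold lower number from compound 2 to compound 3 (2.42 log units; beyond the scatter). Among the compounds with values here, this large step shows that the group here can matter a great deal, but no measured step compares 3-chlorophenyl with 4-methylphenyl directly. The other results also lie at one end of the scale, with the limit of > 100000 nM in this assay, at which 2 of the 3 values shown sit.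

On this thin evidence, a moderate move toward weaker inhibition is expected, smaller than the measured step, and the expected change is a 5.3-fold higher number from compound 3 to compound 4 (0.72 log units; beyond the scatter). For compound 4, the estimated value is 2000 nM, with an expected range of 200 nM to 50000 nM.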

Compound 4, half-maximal inhibitory concentration: 64000 nM
For compound 4 the middle estimate is 32-fold (1.51 log units) below the measured one; measured number outside the range, above it.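

Putting 4-methylphenyl in place of 3-chlorophenyl on an oxygen gives a 170-fold higher number from compound 3 to compound 4 (2.23 log units; beyond the scatter) in this assay, which is a large step. The earlier step changed the number of chlorines on the ring, whereas here both groups have the same count of heavy atoms, a single six-membered aromatic ring and no hydrogen-bond donors or acceptors, so matching counts do not keep the activity at this position. Putting 4-methylphenyl in place of 2,4,6-trichlorophenyl on an oxygen gives an at least 1.5-fold lower number from compound 2 to compound 4 (0.19 log units; that floor lies within the scatter). Putting ethyl in place of hydrogen on a saturated chain carbon bound to an amide-type nitrogen in a ring gives an at least 1.5-fold lower number from compound 1 to compound 4 (0.19 log units; that floor lies within the scatter). Both of these steps start from a limit and not from a number, so each gives only a floor: the limit of > 100000 nM in this assay, at which 2 of the 4 values shown sit.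

This change alters both the substituent and its printed ring number, so the two effects cannot be separated here. Going by these compounds, it remains open whether 4-chlorophenyl or 3-methylphenyl would behave more like compound 3 or like compound 4.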